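This account rests on a few compounds, and the source may have more. Where it says the series, first, only, none or still open, it means among the compounds named here.

Measured in a functional assay on SW-620 cells (Homo sapiens) for cytotoxicity; on this read-out higher numbers stand for weaker inhibition of growth and lower numbers for stronger inhibition of growth:

Compound 1 `COc1ccc(C2=C(c3cc(OC)c(OC)c(OC)c3)CC3CCCN3C2=O)cc1O`: > 100000 nM, a limit of the assay
Compound 2 `COc1ccc(C2=C(c3ccc(SC)cc3)CC3CCCN3C2=O)cc1OC(=O)C1CCCN1C(=O)OC(C)(C)C`: 10000 nM
Compound 3 `CSc1ccc(C2=C(c3ccc(C)c(C)c3)C(=O)N3CCCC3C2)cc1`: 700 nM

Compound 3, at 700 nM, holds the lower of the two actual numbers, and compound 2, at 10000 nM, lies beyond the scatter from it. Compound 1 gives only a limit, > 100000 nM, and no number.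

Compound 4 `CSc1ccc(C2=C(c3ccc(Br)cc3)C(=O)N3CCCC3C2)cc1` differs from compound 3 by 4-bromophenyl in place of 3,4-dimethylphenyl on a double-bonded ring carbon. Within the data shown here, no measured pair shows this change, so only a modest shift towards a higher number is expected. The estimated step in this assay is a 1.4-fold higher number from compound 3 to compound 4 (0.15 log units; within the scatter). For compound 4 the expected value is 1000 nM, with an estimated range of 250 nM to 5000 nM.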

Compound 4, concentration for 50% growth inhibition: 7000 nM
Beside the measured number, compound 4's estimate is 7.0-fold (0.85 log units) below it; the whole stated range lies below it.
By their numbers in this assay, from the lowest: compound 3; then compounds 4 and 2 (each within the scatter of the next). At a limit, above all of these: compound 1.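

In this assay, this first comparison that differs in one place shows that the double-bonded ring carbon is sensitive to the aryl group it carries: a 10-fold higher number from compound 3 to compound 4 (1.00 log units; beyond the scatter). Replacing 3,4-dimethylphenyl with 4-bromophenyl therefore moves the value beyond the scatter, while the 4-(methylsulfanyl)phenyl group stays unchanged. Nothing measured here accounts for the size of this step. Going by these compounds, it remains open whether 4-methylphenyl or 4-chlorophenyl at this position would give values nearer compound 3 or compound 4, and what a phenyl bearing an amine would give.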